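The source may hold more compounds than are shown below. What is called first, only, known or untested is meant among the compounds shown, and "the series" means these compounds.

Compound 3 `O=C(COc1ccc(Oc2ccccc2)cc1)Cn1ncc2cc(NC(=O)Nc3ccccc3)ccc21` belongs to a small set of closely related compounds that share one core and differ only in the group that sits on the aromatic carbon of the fused ring system. In an assay on microsomes from brain for inhibition of Fatty-acid amide hydrolase 1 (Rattus norvegicus), read by fluorescence and HPLC, with a stated time of 45 min (on this read-out lower numbers stand for stronger inhibition and higher numbers for weaker inhibition), compound 3 gives 6000 nM. Its companions are compound 1 `CC(=O)Nc1ccc2c(cnn2CC(=O)COc2ccc(Oc3ccccc3)cc2)c1`, which gives 3900 nM, and compound 2 `COC(=O)Nc1ccc2c(cnn2CC(=O)COc2ccc(Oc3ccccc3)cc2)c1`, which gives 4000 nM; the steps of a 1.5-fold higher number from compound 1 to compound 3 (0.19 log units; within the scatter) and a 1.5-fold higher number from compound 2 to compound 3 (0.18 log units; within the scatter) are both within the scatter, as is a 1.0-fold higher number from compound 1 to compound 2 (0.01 log units; within the scatter), so compound 3 sits among its neighbours rather than apart from them.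

Compound 4 `O=C(COc1ccc(Oc2ccccc2)cc1)Cn1ncc2cc(C(=O)NS(=O)(=O)c3ccccc3)ccc21` carries the next change at the same place: (phenylsulfonyl)carbamoyl in place of (phenylcarbamoyl)amino on an aromatic carbon. The three measured steps all concern exchanges of the group on this aromatic carbon, and none of them moved this assay beyond the scatter. On that basis compound 4 is expected to show a step of no change at the digits printed from compound 3 to compound 4 (within the scatter), that is, no change beyond the scatter. Compound 4 is therefore estimated at 6000 nM, within a range from 2000 nM to 20000 nM.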

Compound 4, half-maximal inhibitory concentration: 4700 nM
Compound 4: the middle estimate sits 1.3-fold (0.11 log units) above what was measured, within the range that was stated.
By their numbers in this assay, from the lowest: compounds 1, 2, 4 and 3 (each within the scatter of the next).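

In this assay, the (phenylsulfonyl)carbamoyl group of compound 4 reads the same, within the scatter, as all three earlier groups: a 1.3-fold lower number from compound 3 to compound 4 (0.11 log units; within the scatter), a 1.2-fold higher number from compound 2 to compound 4 (0.07 log units; within the scatter) and a 1.2-fold higher number from compound 1 to compound 4 (0.08 log units; within the scatter). The earlier groups all reach the aromatic carbon through a nitrogen, whereas this one reaches it through its carbonyl carbon and adds a sulfonyl, so even this larger exchange of linkage leaves the read-out unmoved at this position. No measurement here bears on why the number stays put.

The compounds shown leave open whether a plain amine, a carboxylic acid or a small group such as methoxy on this aromatic carbon would read differently. They also leave open whether any group at this position can separate itself from these four.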